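The source may hold more compounds than are shown below. What is called first, only, known or untested is meant among the compounds shown, and "the series" means these compounds.

Measured compounds:
- compound 1, `Oc1cc(-c2ccccc2)nc2c(F)cccc12`: 0.61 ug/mL
- compound 2, `CCCCOc1cc(-c2ccccc2)nc2ccccc12`: a limit, > 10 ug/mL
- compound 3, `CS(=O)(=O)Oc1cc(-c2ccccc2)nc2ccccc12`: 6.21 ug/mL

These three share one core and differ mainly in the group carried on the oxygen attached to the ring. In a functional assay on A549 cells (Homo sapiens) for cytotoxicity (a lower number here means that less compound is needed, a higher number that more compound is needed for the effect), compound 1 gives 0.61 ug/mL. Compound 2 reaches only a limit of the assay, > 10 ug/mL, and so stands at the limit of > 10 ug/mL in this assay, at which 1 of the 3 values shown sits. Compound 3 gives 6.21 ug/mL, which places it highest of the two plain numbers, above compound 1.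

The unmeasured compound 4, `c1ccc(COc2cc(-c3ccccc3)nc3ccccc23)cc1`, differs from compound 3 in one place: benzyl in place of methylsulfonyl on an oxygen on an aromatic ring. Among the compounds with values here, the only measured step that bears on this is the one from the butyl to the methylsulfonyl group, an at least 1.6-fold lower number from compound 2 to compound 3 (0.20 log units; that floor lies within the scatter). Benzyl, like butyl, is a hydrocarbon group without hydrogen-bond acceptors, so the change to compound 4 runs in the opposite sense of that step, and a somewhat higher number is expected, though the measured step itself lay within the scatter and the starting value of compound 2 is only a limit.

Compound 4 is therefore estimated to give 9 ug/mL, in the range 3.5 ug/mL to 25 ug/mL. That estimate corresponds to a 1.4-fold higher number from compound 3 to compound 4 (0.16 log units; within the scatter).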

Compound 4, half-maximal effective concentration: > 10 ug/mL
Compound 4 was reported as a limit; the forecaster's own chance of this, stated with the estimate: 40%; at least 1.1-fold (0.04 log units) between middle value and limit.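

In this assay compound 4 gives > 10 ug/mL, which is a limit, the second such reading in this set: the limit of > 10 ug/mL in this assay, at which 2 of the 4 values shown sit.

The change from methylsulfonyl to benzyl on this oxygen gives an at least 1.6-fold higher number from compound 3 to compound 4 (0.20 log units; that floor lies within the scatter), so the result adds a second group, this one carrying an aromatic ring, to the butyl of compound 2, and both sit at the limit while only the methylsulfonyl of compound 3 gives a plain number, yet the floor of this step is too small to show a real difference between compound 3 and compound 4. The step between compound 2 and compound 4 cannot be read, as both are limits, so swapping the propyl part of the butyl for the phenyl of the benzyl shows nothing about how the two groups rank.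

From the compounds shown here alone, it remains open whether a chain on this oxygen ending in an amine or a carboxylic acid would bring the number down to a readable value. Also open, going by these compounds, is how a simple acetyl group on the same oxygen would compare with the methylsulfonyl of compound 3.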